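The source may hold more compounds than are shown below. What is called first, only, known or untested is meant among the compounds shown, and "the series" means these compounds.

Compound 3 `C=CC1=C(C(=O)NC(C)(C)C)C(c2ccc(F)cc2)OC1` stands in a functional assay on HeLa cells (Homo sapiens) for cytotoxicity, read by MTT assay, with a stated time of 24 h (on this read-out higher numbers stand for weaker inhibition and lower numbers for stronger inhibition), only at a limit, > 100000 nM. Compound 1 `C=CC1=C(C(=O)NCc2ccc(C)cc2)C(c2ccc(F)cc2)OC1` returns the same limit, > 100000 nM. Compound 2 `C=CC1=C(C(=O)Nc2ccccc2)C(c2ccc(OC)cc2)OC1` likewise gives a limit, > 100000 nM. Going by the values given here, the one measured step between these compounds, a step that the two limits leave unreadable from compound 1 to compound 3, cannot be read, as the limit of > 100000 nM in this assay, at which 3 of the 3 values shown sit, shows. Compound 4 `C=CC1=C(C(=O)Nc2ccccc2)C(c2ccc(F)cc2)OC1` differs from compound 3 by phenyl in place of tert-butyl on an amide-type nitrogen. Compound 2 also carries a phenyl on its amide nitrogen, and its value is a limit. Because the limit of > 100000 nM in this assay, at which 3 of the 3 values shown sit, holds every value at the limit, no direction can be drawn for the change to compound 4. The step that the limit leaves unreadable from compound 3 to compound 4 is therefore expected to stay within the scatter. Compound 4 is estimated to give about 150000 nM, between 50000 nM and 500000 nM, most likely again as a limit.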

Compound 4, half-maximal inhibitory concentration: > 100000 nM
Compound 4: only a limit was reported (the forecaster's own chance of this, stated with the estimate: 85%); the middle value is on the limit's open side.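

In this assay compound 4 gives > 100000 nM, again a limit, so its steps from compound 1, compound 2 and compound 3 cannot be read: the limit of > 100000 nM in this assay, at which 4 of the 4 values shown sit.

The compounds shown leave open whether any change on the amide-type nitrogen or the aromatic carbon would give a readable value in this assay.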